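The compounds below may be only part of what the source reports. "The series", "measured", "known", "first", "only" and "open" are said of these compounds alone.

Measured compounds:
compound 1 `Clc1cccc(Nc2ccc(N3CC4CC(C3)N4)nn2)c1`, 1540 nM
compound 2 `Fc1ccc(Nc2ccc(N3CC4CC(C3)N4)nn2)cc1`, 868 nM
compound 3 `Fc1ccc(Nc2cncc(N3CC4CC(C3)N4)c2)cc1`, 0.091 nM

In an assay on cell membranes for displacement of a labelled ligand from Neuronal acetylcholine receptor; alpha4/beta2 (Rattus norvegicus) (on this read-out lower numbers stand for stronger inhibition and higher numbers for weaker inhibition), compound 2 gives 868 nM, the second highest of the three numbers. Its nearest neighbour is compound 1, which in this assay gives 1540 nM; the two differ in one place only, by the step of a 1.8-fold lower number from compound 1 to compound 2 (0.25 log units; within the scatter). Among the compounds with values here, compound 3 lies far off with 0.091 nM, but it is built on a different core from compound 2, so no single-place step connects the two and the values are merely set side by side.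

Compound 4 `COc1ccc(Nc2ccc(N3CC4CC(C3)N4)nn2)cc1` keeps the core of compound 2 and alters only the substituent on the aryl ring: methoxy in place of fluoro on an aromatic carbon. Within the data shown here, no measured pair exchanges fluoro for methoxy. Among the measured compounds shown here, the only measured step that changes the substituent on this ring, a 1.8-fold lower number from compound 1 to compound 2 (0.25 log units; within the scatter), stayed within the scatter, and nothing else in the set speaks to the change. On that basis no step beyond the scatter is expected in this assay. Compound 4 is therefore estimated at 900 nM, with a range from 300 nM to 2700 nM. On these data alone, the expected step of a 1.0-fold higher number from compound 2 to compound 4 (0.02 log units; within the scatter) is accordingly small, and the wide range reflects that the change itself is untested.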

Compound 4, inhibition constant: 578 nM
Compound 4: middle estimate off by 1.6-fold (0.19 log units), on the high side, within the range that was stated.
By their numbers in this assay, from the lowest: compound 3; then compounds 4, 2 and 1 (each within the scatter of the next, the first and the last beyond it).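

In this assay, methoxy in place of fluoro on an aromatic carbon, para to a large group, gives a 1.5-fold lower number from compound 2 to compound 4 (0.18 log units; within the scatter) and so adds to the series a step in which only the group changes, not its place on the ring. The earlier step among the compounds on this core changed both the halogen and its place, so it could not show how a change of group alone reads at this position. Here the entering group brings one more heavy atom and a hydrogen-bond acceptor that fluoro lacks, and the number still stays within the scatter, while no measurement at hand speaks to what lies behind this result.

On these data alone, whether an amine, a carboxylic acid or a chain longer than methoxy at this same position would produce a step beyond the scatter remains open. The compounds shown also leave open whether fluoro and methoxy would read alike on the core of compound 3, which gives 0.091 nM and has no methoxy partner in the set.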